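Methyl for propenyl ether on the shared pyridine-homopiperazine series

This account rests on a few compounds, and the source may have more. Where it says the series, first, only, none or still open, it means among the compounds named here.

In a functional assay on HEK293 cells for agonist activity at Neuronal acetylcholine receptor; alpha4/beta2 (Homo sapiens), read by FLIPR and calcium flux (on this read-out higher numbers stand for an effect only at larger amounts of compound and lower numbers for an effect already at smaller amounts), compound 2 `C/C=C\Oc1cncc(N2CCCNCC2)c1` gives 2090 nM, the highest of the two numbers recorded so far. For the measured compounds named here, the only comparator, compound 1 `COc1cc(N2CCCNCC2)cnc1Cl`, gives 91.2 nM in this assay, a gap that lies beyond the scatter; no single-point step connects these two compounds, so their values are simply noted side by side. Compound 3 `COc1cncc(N2CCCNCC2)c1` has not been measured. It differs from compound 2 by methyl in place of prop-1-en-1-yl on an oxygen on an aromatic ring. Going by the values given here, with no step between measured compounds to draw on, the expectation rests on the rank of compound 2 alone: as its number sits well above that of compound 1, the shorter ether is expected to move the value downward by a step of moderate size, estimated as a 5.2-fold lower number from compound 2 to compound 3 (0.72 log units; beyond the scatter). For compound 3 the estimate in this assay is 400 nM, with a range from 90 nM to 1800 nM.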

Compound 3, half-maximal effective concentration: 1410 nM
Estimate against measurement, compound 3: 3.5-fold (0.55 log units) below; low and high end bracket the measured number.
By their numbers in this assay, from the lowest: compound 1; then compounds 3 and 2 (each within the scatter of the next).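

In this assay the exchange of prop-1-en-1-yl for methyl on an oxygen on an aromatic ring gives a 1.5-fold lower number from compound 2 to compound 3 (0.17 log units; within the scatter) and so leaves the two ethers indistinguishable on this read-out. The large step in this series lies elsewhere: hydrogen in place of chloro on an aromatic carbon gives a 15-fold higher number from compound 1 to compound 3 (1.19 log units; beyond the scatter) and thus marks that carbon as the more sensitive of the two places compared. No available data bear on the reason for either result.

Going by these compounds, whether a group such as fluoro, bromo, nitrile or an amine on that aromatic carbon would match chloro remains open, as does whether a longer chain or a cyclopropyl group on the oxygen would stay within the scatter. Also open, on these data alone, is whether the chloro step holds with the prop-1-en-1-yl ether in place of methyl.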